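The compounds below may be only part of what the source reports. "The series", "measured", "known", "first", "only" and "open" are said of these compounds alone.

For the measured compounds named here, in an assay on isolated protein (strain Sprague-Dawley) for inhibition of Amine oxidase [flavin-containing] B (Rattus norvegicus), read by spectrophotometry, with a stated time of 5 min (on this read-out higher numbers stand for weaker inhibition and lower numbers for stronger inhibition), compound 1 `CNC(=O)COc1cc(=O)oc2cc(OCc3cccc(Cl)c3)ccc12` gives 33.9 nM and compound 2 `CN(C)C(=O)COc1cc(=O)oc2cc(OCc3cccc(Cl)c3)ccc12` gives 501 nM, the highest of the two numbers measured so far. The step of a 15-fold higher number from compound 1 to compound 2 (1.17 log units; beyond the scatter) goes with a methyl in place of hydrogen on an amide-type nitrogen. Compound 3 `Nc1cc(=O)oc2cc(OCc3cccc(Cl)c3)ccc12` differs from compound 2 by amino in place of (dimethylcarbamoyl)methoxy on an aromatic carbon. Going by the values given here, no measured step covers this change directly; the only one that touches the same side chain, a 15-fold higher number from compound 1 to compound 2 (1.17 log units; beyond the scatter), was large. The step of a 4.2-fold lower number from compound 2 to compound 3 (0.62 log units; beyond the scatter) is therefore expected with little confidence. Compound 3 is estimated at 120 nM, within a range from 10 nM to 1500 nM.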

Compound 3, half-maximal inhibitory concentration: 47.9 nM
Estimate against measurement, compound 3: 2.5-fold (0.40 log units) above; the measured number falls inside the stated range.
By their numbers in this assay, from the lowest: compounds 1 and 3 (each within the scatter of the next); then compound 2.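

Putting amino in place of (dimethylcarbamoyl)methoxy on this aromatic carbon goes with a 10-fold lower number from compound 2 to compound 3 (1.02 log units; beyond the scatter), so a low number here does not require the amide side chain. For the compounds shown here, putting amino in place of (methylcarbamoyl)methoxy gives a 1.4-fold higher number from compound 1 to compound 3 (0.15 log units; within the scatter), so the single amino group and that much larger chain cannot be told apart here. The high number of compound 2 thus stands out among the three.

As far as these compounds go, how a methoxy or dimethylamino group on this carbon would compare with amino stays open. Nothing available explains why these groups give such numbers.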